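Carboxymethyl amide replaces hydroxymethylethyl amide in a pyrrole series

The compounds below may be only part of what the source reports. "The series", "measured", "known", "first", "only" and "open" are said of these compounds alone.

Measured compounds:
compound 1, `CCn1c(C(=O)NCC(=O)OC)ccc1C(CC)(CC)c1ccc(OCS(=O)(=O)c2ccccc2)c(C)c1`, 20000 nM
compound 2, `CCn1c(C(=O)N[C@@H](C)CO)ccc1C(CC)(CC)c1ccc(OCS(=O)(=O)c2ccccc2)c(C)c1`, 15300 nM
compound 3, `CCn1c(C(=O)N[C@H](CO)C(C)C)ccc1C(CC)(CC)c1ccc(OCS(=O)(=O)c2ccccc2)c(C)c1`, 7720 nM

The three measured compounds share a core and differ only in the group on the amide-type nitrogen. In a functional assay on BXPC-3 cells (Homo sapiens) for antiproliferative activity, read by MTT assay, with a stated time of 24 h (a lower number here means a stronger inhibitor, a higher number a weaker inhibitor), compound 2 gives 15300 nM, the second highest of the three numbers. Its nearest neighbour is compound 1 at 20000 nM, a difference described as a 1.3-fold lower number from compound 1 to compound 2 (0.12 log units; within the scatter). Compound 3 at 7720 nM lies further away, with a 2.0-fold lower number from compound 2 to compound 3 (0.30 log units; within the scatter), and the step of a 2.6-fold lower number from compound 1 to compound 3 (0.41 log units; beyond the scatter) is the only one that reaches beyond the scatter.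

Compound 4, `CCn1c(C(=O)NCC(=O)O)ccc1C(CC)(CC)c1ccc(OCS(=O)(=O)c2ccccc2)c(C)c1`, has not yet been measured. Its change from compound 2 is carboxymethyl in place of 1-(hydroxymethyl)ethyl on an amide-type nitrogen. The step that bears on it most directly is a 1.3-fold lower number from compound 1 to compound 2 (0.12 log units; within the scatter), since compound 1 also carries a two-carbon chain ending in a carbonyl on the same nitrogen, and that step stayed within the scatter. Compound 3 shows the only movement beyond the scatter, but that came from a larger branched group, not from a carboxymethyl group.

Compound 4 is therefore expected to stay close to compound 2 in this assay, with a 1.4-fold higher number from compound 2 to compound 4 (0.16 log units; within the scatter), and the estimate is 22000 nM, ranging from 9000 nM to 55000 nM.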

Compound 4, half-maximal inhibitory concentration: > 50000 nM
Compound 4: a limit, no number (the forecaster's own chance of this, stated with the estimate: 20%); middle value at least 2.2-fold (0.35 log units) from the limit.
By their numbers in this assay, from the lowest: compounds 3, 2 and 1 (each within the scatter of the next, the first and the last beyond it). At a limit, above all of these: compound 4.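

In this assay compound 4 gives a limit and not a number: the limit of > 50000 nM in this assay, at which 1 of the 4 values shown sits.

Hydrogen in place of methyl on an oxygen next to a carbonyl group, a change in one place only, gives an at least 2.5-fold higher number from compound 1 to compound 4 (0.39 log units; beyond the scatter), whereas the earlier change on this amide-type nitrogen, a 1.3-fold lower number from compound 1 to compound 2 (0.12 log units; within the scatter), stayed within the scatter. Among these compounds, the carboxymethyl group is also the first group here to move the number upward beyond the scatter from the two hydroxyl-bearing amides, with an at least 3.2-fold higher number from compound 2 to compound 4 (0.51 log units; beyond the scatter) and an at least 6.4-fold higher number from compound 3 to compound 4 (0.81 log units; beyond the scatter), so this position does not tolerate every small group equally in this assay.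

Since the value for compound 4 is a limit, the true size of all three steps stays unknown, and the compounds shown do not tell why the free acid differs from its methyl ester. They also leave open whether the loss belongs to the carboxymethyl group alone or would persist with a carboxylic acid on a longer chain, such as carboxyethyl, or with a primary amide at the end of the same chain.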